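From a fluorocyclobutyl amide to a fluoropiperidine urea

The compounds below may be only part of what the source reports. "The series", "measured", "known", "first", "only" and "open" are said of these compounds alone.

Three measured compounds share one core. Compound 1 `CC(C)CN1CCc2nc(C#Cc3ccccc3)sc2C1` gives 650 nM in an assay on HEK293 cells for negative allosteric modulation of metabotropic glutamate receptor 5 (Homo sapiens), read by FLIPR, with a stated time of 1 h (a higher number here means a weaker inhibitor, a lower number a stronger inhibitor), and compound 3 `O=S(=O)(N1CCCCC1)N1CCc2nc(C#Cc3ccccc3)sc2C1` gives 780 nM in this assay, two values within the usual scatter of each other. Compound 2 `O=C(C1CC(F)C1)N1CCc2nc(C#Cc3ccccc3)sc2C1` reaches only a limit in this assay, reported as > 10000 nM, so for compound 2 a limit stands in place of a number. This is the limit of > 10000 nM in this assay, at which 1 of the 3 values shown sits. Among the measured compounds shown here, the only measured change at the amine nitrogen in the ring is an at least 15-fold higher number from compound 1 to compound 2 (1.18 log units; beyond the scatter), a large loss. For the measured compounds named here, compound 4 `O=C(N1CCC(F)CC1)N1CCc2nc(C#Cc3ccccc3)sc2C1` is not yet measured. 4-fluoropiperidin-1-yl in place of 3-fluorocyclobutyl on a carbonyl carbon No measured step covers this exchange; the nearest guidance is that compound 3, which carries a different group on the same amine nitrogen in the ring, gives 780 nM, showing that another group there still gives a measurable number. Compound 4 is therefore expected to give about 3000 nM, with a likely range from 800 nM to 10000 nM. The expected step of an at least 3.3-fold lower number from compound 2 to compound 4 (0.52 log units; beyond the scatter) points toward a lower number, but its size is uncertain because compound 2 stands at the limit > 10000 nM.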

Compound 4, half-maximal inhibitory concentration: > 10000 nM
Compound 4: no number, only a limit; the forecaster's own chance of this, stated with the estimate: 35%; middle value at least 3.3-fold (0.52 log units) from the limit.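

Compound 2 and compound 4 each reach only a limit rather than a number, so the step between them cannot be read: the limit of > 10000 nM in this assay, at which 2 of the 4 values shown sit.

The compounds shown leave open whether 4-fluoropiperidin-1-yl or 3-fluorocyclobutyl on the carbonyl carbon gives the stronger inhibitor in this assay.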